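Swapping One Phenyl Group for Another: An Expected Outcome

This account rests on a few compounds, and the source may have more. Where it says the series, first, only, none or still open, it means among the compounds named here.

Measured in a functional assay on B16 cells (Mus musculus) for cytotoxicity, read by CCK-8 assay, with a stated time of 24 h; a lower number here means a stronger inhibitor, a higher number a weaker inhibitor:
- compound 1 `COc1ccccc1Oc1c(N)nc(-c2ccccc2F)nc1Cl`: 13800 nM
- compound 2 `COc1ccccc1Oc1c(N)nc(-c2ccc(Cl)cc2)nc1Cl`: 18800 nM

Compound 2 can be compared only with compound 1, and the two values lie within the scatter of each other, so neither can be ranked above the other. Compound 3 `COc1ccccc1Oc1c(N)nc(-c2cccc(Br)c2)nc1Cl` keeps the shared core and changes one group, with 3-bromophenyl in place of 4-chlorophenyl on an aromatic carbon. Within the data shown here, the one measured step that bears on this, a 1.4-fold higher number from compound 1 to compound 2 (0.13 log units; within the scatter), also exchanged one substituted phenyl group for another at the same place. That single example is thin evidence, but it points to no change beyond the scatter in this assay and gives no direction. The expected step is a 1.1-fold lower number from compound 2 to compound 3 (0.04 log units; within the scatter). The estimated value for compound 3 is 17000 nM, with an expected range from 8500 nM to 34000 nM.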

Compound 3, half-maximal inhibitory concentration: 24600 nM
The estimate for compound 3 lay 1.4-fold (0.16 log units) below the measured number, and the stated range covers the measured number.
By their numbers in this assay, from the lowest: compounds 1, 2 and 3 (each within the scatter of the next).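

In this assay, the change to 3-bromophenyl gives a 1.3-fold higher number from compound 2 to compound 3 (0.12 log units; within the scatter) and, measured against the 2-fluorophenyl group, a 1.8-fold higher number from compound 1 to compound 3 (0.25 log units; within the scatter) at this same place on the shared core. Among these compounds, the earlier pair covered only two halogen-bearing phenyl groups, whereas 2-fluorophenyl, 4-chlorophenyl and 3-bromophenyl now give three values that cannot be told apart, even though the halogen and its place on the phenyl ring both differ. Nothing available explains how these three values relate to the structures.

Going by these compounds, what a phenyl ring carrying an amine or a carboxylic acid would do at this place remains open. So does the effect of replacing the whole ring with a longer chain such as butyl, and whether either change would give a step beyond the scatter.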